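The source may report more compounds than this note shows. Statements on the series, on what has been measured and on what is new or still open speak of the compounds shown alone.

Compound 1 `Cc1ccc([C@@H]2CC(c3cccc(O)c3)=NN2c2ccc(S(N)(=O)=O)cc2)cc1` is one of three measured pyrazoline-type sulfonamides, and in a functional assay on the whole organism (strain Wistar albino) for inhibition, with Rattus norvegicus as the target, read by paw edema, with stated times of 30 min and 5 h, at a dose of 0.05 mmol/kg (a lower number here means less inhibition, a higher number more inhibition at the dose given (going by the name of the read-out)), compound 1 gives 66%. Its number is the lowest of the three shown, but only the gap to compound 2 is meaningful: compound 2 `NS(=O)(=O)c1ccc(N2N=C(c3cccc(O)c3)C[C@H]2c2ccc(O)cc2)cc1` gives 77.7%, a step of a number 11.7 percentage points higher from compound 1 to compound 2 (beyond the scatter), whereas compound 3 `NS(=O)(=O)c1ccc(N2N=C(c3cccc(O)c3)C[C@H]2c2ccccc2Cl)cc1` gives 70.3%, a step of a number 4.3 percentage points higher from compound 1 to compound 3 (within the scatter).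

Compound 4 `NS(=O)(=O)c1ccc(N2N=C(c3cccc(O)c3)C[C@H]2/C=C/c2ccccc2)cc1` differs from compound 1 by 2-phenylethenyl in place of 4-methylphenyl on a saturated ring carbon. The two steps that also swap the group on this saturated ring carbon, a number 4.3 percentage points higher from compound 1 to compound 3 (within the scatter) and a number 7.4 percentage points lower from compound 2 to compound 3 (within the scatter), both stayed within the scatter. A step of similar size, not beyond the scatter, is therefore expected here, namely a number 2 percentage points higher from compound 1 to compound 4 (within the scatter). Compound 4 is estimated at 68%, with a likely range from 57% to 79%.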

Compound 4, a percentage reported as inhibition, in the whole organism at one dose (the size of the read-out at that dose, not a potency): 59.2%
Compound 4: middle estimate off by 8.8 percentage points, on the high side; measured number inside the range.
By their numbers in this assay, from the lowest: compounds 4, 1, 3 and 2 (each within the scatter of the next, the first and the last beyond it).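

Swaps at this saturated ring carbon had so far stayed within the scatter, but 2-phenylethenyl now gives steps beyond it against two of the groups (a number 11.1 percentage points lower from compound 3 to compound 4 (beyond the scatter); a number 18.5 percentage points lower from compound 2 to compound 4 (beyond the scatter)). Against 4-methylphenyl the step stays within the scatter (a number 6.8 percentage points lower from compound 1 to compound 4 (within the scatter)), so in this assay the choice of group at this carbon matters only for some pairs. Nothing available explains these gaps. Still open, on these data alone, is how a longer chain without an aromatic ring would compare at this carbon. An amine or a carboxylic acid there also remains untested by the compounds shown.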